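A few compounds are considered here, and "the series" means these few. Any claim that something is new, unique, unknown or untested is made for them only; others in the source may bear on it.

Compounds measured so far:

Compound 1, `CCC1=C(O)c2c(oc(-c3ccc(CC)cc3)cc2=O)C(CC)(CC)C1=O`, gives 21.9 uM in a functional assay on KB cells (Homo sapiens) for antiproliferative activity, read by sulforhodamine B assay, with a stated time of 3 days; a lower number here means that less compound is needed, a higher number that more compound is needed for the effect.
Compound 2, `CCC1=C(O)c2c(oc(-c3ccc(OC)cc3)cc2=O)C(CC)(CC)C1=O`, gives 17.7 uM.
Compound 3, `CCC1=C(O)c2c(oc(-c3ccc(C)c(C)c3)cc2=O)C(CC)(CC)C1=O`, gives 35.5 uM.

All three share one core and differ only in the groups on the attached phenyl ring. The numbers sit close together: the step of a 1.2-fold lower number from compound 1 to compound 2 (0.09 log units; within the scatter) and the step of a 2.0-fold higher number from compound 2 to compound 3 (0.30 log units; within the scatter) are both within the usual scatter, so compound 2 stands at the low end of the three without being separated from the others in any reliable way.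

Compound 4, `CCC1=C(O)c2c(oc(-c3ccc(OC)c(C)c3)cc2=O)C(CC)(CC)C1=O`, has not been measured. It differs from compound 2 by methyl in place of hydrogen on an aromatic carbon; cut one bond further out, this reads as 4-methoxyphenyl to 4-methoxy-3-methylphenyl. Among the compounds with values here, the steps that bear on this are a 2.0-fold higher number from compound 2 to compound 3 (0.30 log units; within the scatter) and a 1.6-fold higher number from compound 1 to compound 3 (0.21 log units; within the scatter), where the phenyl ring carried a methyl at the 3-position; both were modest and within scatter. A small drift to a higher number, or no step beyond scatter, is therefore expected: a 1.2-fold higher number from compound 2 to compound 4 (0.09 log units; within the scatter). Compound 4 is estimated at 22 uM, with a range from 10 uM to 45 uM.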

Compound 4, concentration for half-maximal effect: 28.5 uM
Compound 4: middle estimate off by 1.3-fold (0.11 log units), on the low side, and the stated range covers the measured number.
By their numbers in this assay, from the lowest: compounds 2, 1, 4 and 3 (each within the scatter of the next).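

Methyl in place of hydrogen, ortho to a methoxy group, gives a step that stays within the usual scatter in this assay: a 1.6-fold higher number from compound 2 to compound 4 (0.21 log units; within the scatter). Within the data shown here, compound 4 is the first here to carry methoxy and methyl together on the phenyl ring, and neither comparison with the earlier compounds separates it from them: a 1.2-fold lower number from compound 3 to compound 4 (0.10 log units; within the scatter), and a 1.3-fold higher number from compound 1 to compound 4 (0.11 log units; within the scatter). So, among these compounds, this position accepts a methyl without any reliable shift, whether the group ortho to it is methoxy or methyl.

Going by these compounds, whether an amine, a carboxylic acid or a longer chain such as propyl at this same position would give a step beyond the scatter remains open. Nothing available here offers an explanation for these small differences.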